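Swapping the aryl group on the oxazole ketone core

A few compounds are considered here, and "the series" means these few. Any claim that something is new, unique, unknown or untested is made for them only; others in the source may bear on it.

Compound 3 `N#Cc1ccc(-c2cnc(C(=O)CCCCCCc3ccccc3)o2)cc1`: 40 nM
Compound 1 `O=C(CCCCCCc1ccccc1)c1ncc(-c2ccccc2F)o1`: 110 nM
Compound 2 `COc1ccccc1-c1cnc(C(=O)CCCCCCc2ccccc2)o1`: 400 nM

In an assay (Rattus norvegicus) for inhibition of Fatty-acid amide hydrolase 1 (Homo sapiens) (a higher number here means a weaker inhibitor, a lower number a stronger inhibitor), compound 3 gives the lowest number of the three, with a 2.8-fold lower number from compound 1 to compound 3 (0.44 log units; beyond the scatter) and a 10-fold lower number from compound 2 to compound 3 (1.00 log units; beyond the scatter) both beyond the scatter. Compound 4 `O=C(CCCCCCc1ccccc1)c1ncc(-c2ncccn2)o1` is the next step: pyrimidin-2-yl in place of 4-cyanophenyl on an aromatic carbon. For the measured compounds named here, no measured step touches a pyrimidin-2-yl, so only the size of the known aryl swaps is a guide: a 3.6-fold higher number from compound 1 to compound 2 (0.56 log units; beyond the scatter) and a 10-fold lower number from compound 2 to compound 3 (1.00 log units; beyond the scatter) show that changing this group moves the number by a modest amount. Since compound 3 holds the lowest number, a loss is expected, a 3.0-fold higher number from compound 3 to compound 4 (0.48 log units; beyond the scatter). Compound 4 is therefore estimated at 120 nM, within 35 nM to 450 nM.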

Compound 4, inhibition constant: 5.3 nM
Beside the measured number, compound 4's estimate is 23-fold (1.35 log units) above it; measured number outside the range, below it.
By their numbers in this assay, from the lowest: compound 4; then compound 3; then compound 1; then compound 2.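

In this assay, replacing the carbon-only aromatic ring with pyrimidin-2-yl gives the strongest inhibitor of the four: a 7.5-fold lower number from compound 3 to compound 4 (0.88 log units; beyond the scatter), a 21-fold lower number from compound 1 to compound 4 (1.32 log units; beyond the scatter) and a 75-fold lower number from compound 2 to compound 4 (1.88 log units; beyond the scatter). The earlier compounds shown here changed only the group carried on a phenyl ring, whereas this step changes the ring itself and shows that the nitrile of compound 3 is not needed for a low number. No measurement shown explains the gain. The compounds shown leave open whether a pyridin-2-yl group, with a single ring nitrogen, would do as well. They also leave open how an amine on the pyrimidine ring would change the number.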